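Swapping a saturated ring for a second aryl group

The source may report more compounds than this note shows. Statements on the series, on what has been measured and on what is new or still open speak of the compounds shown alone.

Going by the values given here, compound 1 `CC(C)(C)[C@H]1CC[C@H](c2cc(-c3ccc(OC(F)(F)F)cc3)nn2Cc2ccc(C(=O)NCCC(=O)O)cc2)CC1` is one of three compounds measured in an assay on CHO cells for displacement of a labelled ligand from Glucagon receptor (Homo sapiens); a lower number here means a stronger inhibitor, a higher number a weaker inhibitor. In this assay compound 1 gives 480 nM, the second highest of the three numbers. Compound 2 `O=C(O)CCNC(=O)c1ccc(Cc2cn(-c3ccc(OC(F)(F)F)cc3)nc2C2CCCCC2)cc1` gives 1200 nM in this assay, a higher number than compound 1. Among the compounds with values here, compound 3 `CC(C)(C)[C@H]1CC[C@H](c2cc(-c3ccc(OC(F)(F)F)cc3)nn2Cc2ccc(C(=O)Nc3nn[nH]n3)cc2)CC1`, which carries a 2H-tetrazol-5-yl in place of the 2-carboxyethyl on the amide-type nitrogen, gives 63 nM in this assay, and the step of a 7.6-fold lower number from compound 1 to compound 3 (0.88 log units; beyond the scatter) is the only one-place change among the measured compounds.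

Compound 4 `O=C(O)CCNC(=O)c1ccc(Cn2nc(-c3ccc(OC(F)(F)F)cc3)cc2-c2ccc(OC(F)(F)F)cc2)cc1` has not yet been measured. It differs from compound 1 in one place: 4-(trifluoromethoxy)phenyl in place of 4-(tert-butyl)cyclohexyl on an aromatic carbon. Within the data shown here, none of the measured steps touches this position; the step from compound 1 to compound 3 concerns the acidic end of the molecule and says nothing about the group on the five-membered ring. Among the measured compounds shown here, the only measured compound without the tert-butylcyclohexyl, compound 2, differs from compound 1 in more than one place, so its higher number cannot be read as a guide to this single swap.

For the measured compounds named here, with no direct precedent, the expectation for compound 4 is a weak one, leaning toward a somewhat higher number, and the step is estimated as a 1.9-fold higher number from compound 1 to compound 4 (0.27 log units; within the scatter). Compound 4 is therefore expected to give about 900 nM in this assay, within a range from 200 nM to 4000 nM.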

Compound 4, half-maximal inhibitory concentration: 490 nM
Estimate against measurement, compound 4: 1.8-fold (0.26 log units) above; measured number inside the range.
By their numbers in this assay, from the lowest: compound 3; then compounds 1 and 4 (each within the scatter of the next); then compound 2.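

In this assay, the swap at this position gives a 1.0-fold higher number from compound 1 to compound 4 (0.01 log units; within the scatter). Going by these compounds alone, the change is a real one in structure: a six-membered non-aromatic ring of carbon only, with 2 defined stereocentres, leaves, and a six-membered aromatic ring carrying oxygen and fluorine enters, so for this pair the 4-(tert-butyl)cyclohexyl is not needed to keep the number where it stands, something the earlier compounds could not show. Nothing available explains why two such different groups give matching numbers here.

A single pair cannot separate the ring from what it carries, so a plain phenyl, a 4-(tert-butyl)phenyl or a plain cyclohexyl at this position would be needed to tell those two parts apart. Going by these compounds, it also stays open whether the 2H-tetrazol-5-yl, which gives a 7.6-fold lower number from compound 1 to compound 3 (0.88 log units; beyond the scatter) on the tert-butylcyclohexyl compounds, would act the same way alongside the 4-(trifluoromethoxy)phenyl group of compound 4.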